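The source may report more compounds than this note shows. Statements on the series, on what has been measured and on what is new or still open speak of the compounds shown alone.

Compound 3 `Cn1cnnc1-c1cccc(NC(=O)C2CCCN(C(=O)c3cc(C(F)(F)F)cc(C(F)(F)F)c3)C2)c1` belongs to a small set sharing one core, on which a group at an aromatic carbon is varied. In an ADME assay on PC-3 cells (Homo sapiens) for cytotoxicity, read by WST assay, tested at 100 uM (on this read-out lower numbers stand for less inhibition and higher numbers for more inhibition at the one concentration tested (going by the name of the read-out)), compound 3 gives 0%. Compound 2 `CC(=O)c1cccc(NC(=O)C2CCCN(C(=O)c3cc(C(F)(F)F)cc(C(F)(F)F)c3)C2)c1` gives 0% in this assay, and compound 1 `O=C(Nc1cccc(Oc2ccccc2)c1)C1CCCN(C(=O)c2cc(C(F)(F)F)cc(C(F)(F)F)c2)C1` gives 1% in this assay; all three numbers sit within the scatter of one another, so nothing sets compound 3 apart from its neighbours on this read-out.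

The next compound, compound 4 `Cc1nc(-c2cccc(NC(=O)C3CCCN(C(=O)c4cc(C(F)(F)F)cc(C(F)(F)F)c4)C3)c2)cs1`, differs from compound 3 in one place: 2-methyl-1,3-thiazol-4-yl in place of 4-methyl-4H-1,2,4-triazol-3-yl on an aromatic carbon. The steps already seen bear on this exchange of one aromatic substituent for another. From compound 2 to compound 3 the read-out moved no change at the digits printed from compound 2 to compound 3 (within the scatter), from compound 1 to compound 3 it moved a number 1 percentage points lower from compound 1 to compound 3 (within the scatter), and from compound 1 to compound 2 it moved a number 1 percentage points lower from compound 1 to compound 2 (within the scatter). Every replacement at this aromatic carbon so far has left the read-out unchanged beyond the scatter, and nothing in the data argues that the present one should behave otherwise. Compound 4 is therefore expected to show a step of a number 1 percentage points higher from compound 3 to compound 4 (within the scatter), no change beyond the scatter. Compound 4 is estimated at 1%, with a range from 0% to 8%.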

Compound 4, a percentage reported as inhibition, at one concentration (the size of the read-out at that concentration, not a potency): 1%
The estimate for compound 4 equals the measured number at the digits printed; the range from low to high includes it.
By their numbers in this assay, from the lowest: compounds 2, 3, 1 and 4 (each within the scatter of the next).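

In this assay the 2-methyl-1,3-thiazol-4-yl group fits with the groups already seen at this aromatic carbon: the read-out shows a number 1 percentage points higher from compound 3 to compound 4 (within the scatter) and a number 1 percentage points higher from compound 2 to compound 4 (within the scatter) and also no change at the digits printed from compound 1 to compound 4 (within the scatter) on the same shared core. This extends the earlier picture to a group that carries sulfur, which none of the three earlier groups does, and to a direct exchange of one five-membered aromatic ring for another, so the four groups at this place, meta to a large group, cannot be told apart on this read-out. No measured evidence is available to explain this result.

The compounds shown leave open whether a primary amine or a carboxylic acid on this aromatic carbon would give a reading beyond the scatter of these four compounds. They also leave open what a change elsewhere on the shared core would do, such as an amine in place of one trifluoromethyl group, since only this one place is varied here.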